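Adding Chloro to Compound 2: What Compound 3 May Show

The source may hold more compounds than are shown below. What is called first, only, known or untested is meant among the compounds shown, and "the series" means these compounds.

Of the compounds shown here, two sharing one core have been tested in a functional assay on NCI-H460 cells (Homo sapiens) for inhibition, read by sulforhodamine B assay, with a stated time of 48 h, tested at 10 uM; on this read-out lower numbers stand for a stronger effect and higher numbers for a weaker effect at the one concentration tested. Compound 1 `COc1cc2cc(Oc3ccc(NC(=O)Nc4ccc(C)cc4)cc3)c(C)nc2cc1OC` gives 108% in this assay, while compound 2 `COc1cc2cc(Oc3ccc(NC(=O)Nc4cccc(C(F)(F)F)c4)cc3)c(C)nc2cc1OC` gives 2.68%. Among the measured compounds shown here, the one step between them, a number 105.3 percentage points lower from compound 1 to compound 2 (beyond the scatter), places compound 2 at the lower of the two numbers, separated from compound 1 by a gap beyond the scatter.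

Compound 3 `COc1cc2cc(Oc3ccc(NC(=O)Nc4ccc(Cl)c(C(F)(F)F)c4)cc3)c(C)nc2cc1OC` is not yet measured. Compared with compound 2 it carries chloro in place of hydrogen on an aromatic carbon. For the measured compounds named here, no measured step concerns chloro in place of hydrogen on an aromatic carbon; the single step on record, a number 105.3 percentage points lower from compound 1 to compound 2 (beyond the scatter), turns on the exchange of one whole aryl group for another and so does not speak directly to this smaller change. Since compound 2 already stands at 2.68%, little room remains for a further fall, and a step beyond the scatter in either direction is not expected. For compound 3 the expected value in this assay is 4%, with a range from 0% to 18%, which means an expected step of a number 1.3 percentage points higher from compound 2 to compound 3 (within the scatter).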

Compound 3, a percentage reported as activity, at one concentration (the size of the read-out at that concentration, not a potency): -19.8%
Compound 3: the middle estimate sits 23.8 percentage points above what was measured; measured number outside the range, below it.
By their numbers in this assay, from the lowest: compound 3; then compound 2; then compound 1.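

In this assay, chloro in place of hydrogen on an aromatic carbon, ortho to a trifluoromethyl group and para to a large group, gives a number 22.5 percentage points lower from compound 2 to compound 3 (beyond the scatter), so this position still responds to a single added chlorine atom on a ring that already carries trifluoromethyl. Compound 2 had therefore not reached the bottom of the read-out, since compound 3 gives -19.8%, a negative number, and the full exchange of aryl groups now comes to a number 127.8 percentage points lower from compound 1 to compound 3 (beyond the scatter). No measurement shown here accounts for the step from hydrogen to chloro.

The compounds shown do not tell whether chloro would have a similar effect without the trifluoromethyl group, as a 4-chlorophenyl group on the shared core is not among them. They also leave open whether this step is particular to chloro or would also appear with fluoro, methoxy, an amine or a carboxylic acid at the same position, and a reading at one concentration gives no potency for any of these compounds.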